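Furan-2-yl in Place of Nitrophenyl: An Antiproliferative Step

A few compounds are considered here, and "the series" means these few. Any claim that something is new, unique, unknown or untested is made for them only; others in the source may bear on it.

Compound 1, `N#CC1=C(N)N(c2ccc(S(N)(=O)=O)cc2)C2=C(C(=O)CCC2)C1c1ccccc1`: 40%
Compound 2, `COc1ccc(C2C(C#N)=C(N)N(c3ccc(S(N)(=O)=O)cc3)C3=C2C(=O)CCC3)cc1`: 90%
Compound 3, `N#CC1=C(N)N(c2ccc(S(N)(=O)=O)cc2)C2=C(C(=O)CCC2)C1c1ccc([N+](=O)[O-])cc1`: 95%

These three compounds were tested in a functional assay on Ehrlich cells (Mus musculus) for antiproliferative activity, read by trypan blue exclusion, with a stated time of 2 h, tested at 50 ug/mL; a lower number here means a weaker effect, a higher number a stronger effect of the compound at the concentration tested. Compound 3 gives the highest number of the three; compound 2 sits close to it, with a number 5 percentage points higher from compound 2 to compound 3 (within the scatter), while compound 1 lies well behind, with a number 55 percentage points higher from compound 1 to compound 3 (beyond the scatter). Compound 4, `N#CC1=C(N)N(c2ccc(S(N)(=O)=O)cc2)C2=C(C(=O)CCC2)C1c1ccco1`, has not yet been tested. It differs from compound 3 in one place: furan-2-yl in place of 4-nitrophenyl on a saturated ring carbon. Among the measured compounds shown here, none of the measured steps exchanges the whole ring; each only alters what the six-membered ring carries, so they bear on this change only indirectly. Both a number 50 percentage points higher from compound 1 to compound 2 (beyond the scatter) and a number 55 percentage points higher from compound 1 to compound 3 (beyond the scatter) show that compound 1, with hydrogen at that aromatic carbon, gives a much lower number than the compounds carrying methoxy or nitro there. The furan-2-yl carries no such group, so the expectation leans toward a weaker result than compound 3, though a five-membered ring with one hetero atom is a different ring and the data give no direct guide. For compound 4 the expected step is a number 35 percentage points lower from compound 3 to compound 4 (beyond the scatter). Compound 4 is therefore estimated at 60%, with a range from 30% to 90%.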

Compound 4, a percentage reported as activity, at one concentration (the size of the read-out at that concentration, not a potency): 5%
Beside the measured number, compound 4's estimate is 55 percentage points above it; the measured number lies below the stated range.
By their numbers in this assay, from the lowest: compound 4; then compound 1; then compounds 2 and 3 (each within the scatter of the next).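

Swapping the whole six-membered aromatic ring at this saturated ring carbon, a change none of the earlier steps made, costs a large amount in this assay whichever ring leaves: there is a number 90 percentage points lower from compound 3 to compound 4 (beyond the scatter) and a number 85 percentage points lower from compound 2 to compound 4 (beyond the scatter) and also a number 35 percentage points lower from compound 1 to compound 4 (beyond the scatter) in the same test. The earlier compounds shown here showed only that methoxy or nitro on the phenyl gives a higher number than hydrogen, and that left compound 1 as the lowest point seen so far; furan-2-yl now falls beyond the scatter below that point, so at this position the identity of the ring matters as well as what it carries. Nothing available here explains this drop.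

The compounds shown leave open whether the low number belongs to the five-membered ring as such or to its ring oxygen, a question that thiophen-2-yl or pyridin-3-yl at the same carbon would bear on. Also open, from the compounds shown here alone, is whether a nitro or methoxy group on the furan-2-yl ring would raise the number as those groups do on the phenyl ring of compound 1 .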